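This account rests on a few compounds, and the source may have more. Where it says the series, first, only, none or still open, it means among the compounds named here.

In a functional assay on HT-29 cells (Homo sapiens) for antiproliferative activity, read by sulforhodamine B assay, with a stated time of 48 h (on this read-out higher numbers stand for weaker inhibition and lower numbers for stronger inhibition), compound 1 (`O=C1NCCN1c1ccc(S(=O)(=O)Nc2ccccc2)cc1`) gives 280 nM and compound 2 (`Cc1ccc(NS(=O)(=O)c2ccc(N3CCNC3=O)cc2)c(C)c1`) gives 180 nM. For the measured compounds named here, these are the only two numbers available, and they lie within the scatter of each other, so compound 1 cannot be separated from its one neighbour. Compound 3 (`O=C1NCCN1c1ccc(S(=O)(=O)Nc2cccc(Oc3ccccc3)c2)cc1`) differs from compound 1 by a single change: phenoxy in place of hydrogen on an aromatic carbon. Going by the values given here, the only measured step that bears on this is a 1.6-fold lower number from compound 1 to compound 2 (0.19 log units; within the scatter), which has 2,4-dimethylphenyl in place of phenyl on a sulfonamide nitrogen. Among the compounds with values here, no measured compound carries phenoxy, so that step offers only weak guidance. A small step toward a higher number is expected in this assay, with wide uncertainty in either direction. For compound 3 the estimated value is 450 nM, with an expected range from 100 nM to 2000 nM. This estimate means an expected 1.6-fold higher number from compound 1 to compound 3 (0.21 log units; within the scatter).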

Compound 3, half-maximal inhibitory concentration: 200 nM
Compound 3: the middle estimate sits 2.3-fold (0.35 log units) above what was measured; low and high end bracket the measured number.
By their numbers in this assay, from the lowest: compounds 2, 3 and 1 (each within the scatter of the next).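

In this assay phenoxy in place of hydrogen on an aromatic carbon, meta to a large group, gives a 1.4-fold lower number from compound 1 to compound 3 (0.15 log units; within the scatter) and so leaves compound 3 not separable from compound 1. For the compounds shown here, this shows what the earlier compounds did not: this carbon can carry phenoxy, with its 7 heavy atoms and one further six-membered aromatic ring, without a change that stands out from the scatter. No measurement at hand offers an explanation for this result.

As far as these compounds go, whether the same holds for an amine, a carboxylic acid or a longer chain on this carbon remains open. Also open, from the compounds shown here alone, is whether phenoxy would give a comparable number on another carbon of the same ring, or whether a larger group such as benzyloxy would still fall within the scatter of compound 1.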